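This account rests on a few compounds, and the source may have more. Where it says the series, first, only, none or still open, it means among the compounds named here.

Compound 1 `CCOc1ccccc1-c1ccc(-c2nc3cnccc3c(NC(C(N)=O)C3CC3)c2C#N)cc1` is the more lipophilic of the two compounds measured in a physicochemical assay for lipophilicity, read by HPLC, at pH 7.5 (a lower number here means a more polar compound, a higher number a more lipophilic compound), giving 3. Compound 2 `CC[C@@H](Nc1c(C#N)c(-c2ccc(Br)cc2)nc2cnccc12)C(=O)O` sits clearly lower in this assay, at 1.6, a gap beyond the usual scatter. Compound 3 `CCOc1ccccc1-c1ccc(-c2nc3cnccc3c(NC(CC)CNS(=O)(=O)C3CC3)c2C#N)cc1` has not yet been measured; it differs from compound 1 by a group of 11 heavy atoms (7 carbon, 1 nitrogen, 2 oxygen, 1 sulfur; one three-membered non-aromatic ring of carbon only) in place of a group of 7 heavy atoms (5 carbon, 1 nitrogen, 1 oxygen; one three-membered non-aromatic ring of carbon only), on a nitrogen on an aromatic ring. For the measured compounds named here, with no measured step of this kind to lean on, a modest rise is expected, one that may not exceed the scatter, since the entering group is larger but also brings a further acceptor. For compound 3 the estimated value in this assay is 3.3, within 2.7 to 3.9, an expected step of a number 0.30 log units higher from compound 1 to compound 3 (within the scatter).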

Compound 3, distribution coefficient: 3.6
Estimate against measurement, compound 3: 0.30 log units below, and the stated range covers the measured number.
By their numbers in this assay, from the lowest: compound 2; then compound 1; then compound 3.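

In this assay, for the compounds shown here, the group of 11 heavy atoms, in place of the group of 7 heavy atoms on a nitrogen on an aromatic ring, gives a number 0.60 log units higher from compound 1 to compound 3 (beyond the scatter) and so provides the only change in one place that can be read here. Compound 1 and compound 2 differ in more than one place, so they could not show what a change at this nitrogen alone does. Nothing available explains the size of this step.
On these data alone, whether other groups on this nitrogen, such as a simple amine or a longer alkyl chain, would move the number in the same direction remains open. So does whether this step would carry over to a core with a different aromatic substituent.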